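Working notes: from compound 2 to compound 4

A few compounds are considered here, and "the series" means these few. Any claim that something is new, unique, unknown or untested is made for them only; others in the source may bear on it.

- compound 1 `Cc1ncccc1-c1cnc(NCc2c(F)ccc3c2CCO3)c2ncc(=O)[nH]c12` gives 2.8
- compound 2 `O=C1CCCN1c1cnc(NCc2c(F)ccc3c2CCO3)c2cn[nH]c(=O)c12` gives 1.8
- compound 3 `CC1(C)CC(=O)N(c2cnc(NCc3c(F)ccc4c3CCO4)n3cnnc23)C1` gives 2

In a physicochemical assay for lipophilicity, using the shake flask method, in phosphate buffer, measured as octanol-water partition, with a stated time of 30 min, at pH 7.4 (on this read-out lower numbers stand for lower lipophilicity and higher numbers for higher lipophilicity), compound 2 gives 1.8. That number lies within the scatter of the number of compound 3, and the gap to the number of compound 1 lies beyond the scatter.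

Compound 4 `CNC(=O)c1ncc(-c2cnc(NCc3c(F)ccc4c3CCO4)c3cn[nH]c(=O)c23)n1C` keeps the core of compound 2 and carries 1-methyl-2-(methylcarbamoyl)-1H-imidazol-5-yl in place of 2-oxopyrrolidin-1-yl on an aromatic carbon.

For the measured compounds named here, no two measured compounds differ in only one place, so the data offer no direct precedent for this change. No shift beyond the scatter is expected in this assay, and the estimated step is a number 0.20 log units higher from compound 2 to compound 4 (within the scatter). For compound 4 the expected value is 2, with an estimated range of 1.5 to 2.6.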

Compound 4, distribution coefficient: 2.5
Estimate against measurement, compound 4: 0.50 log units below; the measured number falls inside the stated range.
By their numbers in this assay, from the lowest: compounds 2 and 3 (each within the scatter of the next); then compounds 4 and 1 (each within the scatter of the next).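

In this assay, for the compounds shown here, 1-methyl-2-(methylcarbamoyl)-1H-imidazol-5-yl in place of 2-oxopyrrolidin-1-yl on an aromatic carbon gives a number 0.70 log units higher from compound 2 to compound 4 (beyond the scatter), the first step that differs in one place. This position therefore moves the read-out beyond the scatter. The number rises although the entering group carries 1 hydrogen-bond donor and 3 hydrogen-bond acceptors, against 0 and 1 in the group that leaves.

Open, from the compounds shown here alone, is whether the methylcarbamoyl part carries the step, and how a carboxylic acid or an amine would read here. No measurement bears on the origin of this step.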